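The source may hold more compounds than are shown below. What is called first, only, known or untested is meant among the compounds shown, and "the series" means these compounds.

Measured in a functional assay on MCF7 cells (Homo sapiens) for cytotoxicity, read by MTT assay, with a stated time of 48 h; on this read-out higher numbers stand for weaker inhibition and lower numbers for stronger inhibition:
compound 1 `C/C(=N\NC(=S)Nc1ccc(I)cc1)c1ccccn1`: 6.61 nM
compound 2 `CC(=NNC(=S)Nc1ccccc1)c1ccccn1`: 0.18 nM

In this assay, compound 2 stands lowest of the two, at 0.18 nM, and so shows the stronger inhibition. Compound 1 gives 6.61 nM. The gap between the two compounds lies beyond the scatter. Compound 3 `CC(=NNC(=S)Nc1ccc(I)cc1)c1ccccn1` has not yet been measured. It differs from compound 2 by a single change, iodo in place of hydrogen on an aromatic carbon, para to a large group. Among the measured compounds shown here, compound 1 also carries an iodo group, and with compound 1 at 6.61 nM as the only guide, a rise beyond the scatter is expected, towards weaker inhibition and close in size to the gap between the two measured compounds. The expected change is a 22-fold higher number from compound 2 to compound 3 (1.35 log units; beyond the scatter). For compound 3 the estimated value is 4 nM, with an expected range of 0.8 nM to 15 nM.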

Compound 3, half-maximal inhibitory concentration: 6.6 nM
For compound 3 the middle estimate is 1.7-fold (0.22 log units) below the measured one; the measured number falls inside the stated range.
By their numbers in this assay, from the lowest: compound 2; then compounds 3 and 1 (each within the scatter of the next).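

In this assay, iodo in place of hydrogen on an aromatic carbon, para to a large group, can now be read as a change in one place: a 37-fold higher number from compound 2 to compound 3 (1.56 log units; beyond the scatter). Compound 1 carries the same iodo group but also a drawn double-bond configuration, so it could not show this on its own. The second step, a 1.0-fold lower number from compound 1 to compound 3 (0.00 log units; within the scatter), lies within the scatter and rests on a difference in the drawing alone: the fact that one of compounds 1 and 3 is drawn with a defined configuration and the other without, at the place where they differ

The compounds shown leave open whether this large step belongs to iodo in particular or would also follow from another group at this place, such as fluoro, methoxy or an amine. They also leave open what the double-bond configuration contributes, since the configuration of compound 3 is not drawn.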